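Swapping Difluorophenyl for Chlorophenyl on the Shared Core

A few compounds are considered here, and "the series" means these few. Any claim that something is new, unique, unknown or untested is made for them only; others in the source may bear on it.

Within the data shown here, compound 2 `Fc1ccc(Nc2cc(Nc3ccc(Oc4ccncc4-c4cccnc4)c(F)c3)ncn2)cc1F` stands at the lowest number of the two measured so far: in a functional assay on MKN-45 cells (Homo sapiens) for cytotoxicity, read by MTT assay, with a stated time of 72 h (on this read-out higher numbers stand for weaker inhibition and lower numbers for stronger inhibition), compound 2 gives 80 nM. Its nearest neighbour, compound 1 `COc1ccc(Nc2cc(Nc3ccc(Oc4ccncc4-c4cccnc4)c(F)c3)ncn2)cc1`, differs only in the group on a nitrogen on an aromatic ring, and in this assay compound 1 gives 1010 nM. That single change produced a 13-fold lower number from compound 1 to compound 2 (1.10 log units; beyond the scatter), a large step.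

Compound 3 `Fc1cc(Nc2cc(Nc3ccc(Cl)cc3)ncn2)ccc1Oc1ccncc1-c1cccnc1` is not yet measured. It differs from compound 2 by 4-chlorophenyl in place of 3,4-difluorophenyl on a nitrogen on an aromatic ring. Among the measured compounds shown here, only one measured step bears on this site, the step from compound 1 to compound 2, and it shows that this group can move the number by a large margin. Both the leaving 3,4-difluorophenyl and the entering 4-chlorophenyl carry halogen rather than the methoxy of compound 1, so the step is expected to be small: for compound 3 the expected step is a 1.9-fold higher number from compound 2 to compound 3 (0.27 log units; within the scatter). Compound 3 is therefore estimated at 150 nM in this assay, with a plausible range from 50 nM to 500 nM.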

Compound 3, half-maximal inhibitory concentration: 240 nM
Compound 3: middle estimate off by 1.6-fold (0.20 log units), on the low side; the range from low to high includes it.
By their numbers in this assay, from the lowest: compound 2; then compound 3; then compound 1.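

In this assay, the two halogen-bearing groups at this site are not interchangeable: 4-chlorophenyl in place of 3,4-difluorophenyl gives a 3.0-fold higher number from compound 2 to compound 3 (0.48 log units; beyond the scatter), so carrying halogen is not all that matters on this nitrogen. Chloro in place of methoxy on an aromatic carbon still gives a 4.2-fold lower number from compound 1 to compound 3 (0.62 log units; beyond the scatter), which places the three groups in a clear order, from 3,4-difluorophenyl at the lowest number, through 4-chlorophenyl, to 4-methoxyphenyl at the highest. Nothing measured alongside these numbers accounts for that order.

The step from compound 2 to compound 3 changes two things at once, since one fluorine is gone and the other has given way to chlorine, so these compounds cannot say which of the two carries the step. A 4-fluorophenyl group on the same nitrogen would separate the two changes, while a phenyl ring bearing an amine or a carboxylic acid, or a longer chain in place of the ring, would test how much this site tolerates beyond halogen and methoxy.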